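A few compounds are considered here, and "the series" means these few. Any claim that something is new, unique, unknown or untested is made for them only; others in the source may bear on it.

The series shares the core of compound 1 `Nc1n/c(=N\CCCCc2ccccc2)nc(N)c2c1ncn2Cc1ccccc1`, which in a functional assay on A549 cells (Homo sapiens) for antiproliferative activity, read by WST assay, with a stated time of 72 h (a lower number here means a stronger inhibitor, a higher number a weaker inhibitor), gives 15300 nM. Exchanging the phenyl at the end of the chain for an alkyl lowers the number: compound 2 `CCCCCCCCCCCCCC/N=c1\nc(N)c2ncn(Cc3ccccc3)c2c(N)n1` gives 4250 nM, a change of a 3.6-fold lower number from compound 1 to compound 2 (0.56 log units; beyond the scatter), and compound 3 `CCCCCCCC/N=c1\nc(N)c2ncn(Cc3ccccc3)c2c(N)n1` gives 3830 nM, a change of a 4.0-fold lower number from compound 1 to compound 3 (0.60 log units; beyond the scatter). Between the two alkyl analogues the step of a 1.1-fold lower number from compound 2 to compound 3 (0.05 log units; within the scatter) stays within the scatter, so compound 3 holds the lowest of the three numbers but is not separated from compound 2 by a step that counts.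

Compound 4 `CCCCCCCC/N=c1\nc(N)c2ncn(Cc3ccc(OC)cc3)c2c(N)n1` differs from compound 3 by methoxy in place of hydrogen on an aromatic carbon. For the measured compounds named here, all three measured steps concern the chain attached to the double-bonded nitrogen; none touches the benzyl group on the core, so no measured step bears directly on this change. With nothing in the series to argue for a shift in either direction, the working expectation is a number close to that of compound 3, and the step of a 1.0-fold lower number from compound 3 to compound 4 (0.00 log units; within the scatter) is expected to remain within the scatter. Compound 4 is accordingly estimated at 3800 nM in this assay, with a range of 1500 nM to 9500 nM.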

Compound 4, half-maximal inhibitory concentration: 5700 nM
For compound 4 the middle estimate is 1.5-fold (0.18 log units) below the measured one, and the stated range covers the measured number.
By their numbers in this assay, from the lowest: compounds 3, 2 and 4 (each within the scatter of the next); then compound 1.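

For the compounds shown here, this is the first measured change on the benzyl group rather than on the chain attached to the double-bonded nitrogen. In this assay, placing methoxy on an aromatic carbon of the six-membered aromatic ring, para to a large group, gives a 1.5-fold higher number from compound 3 to compound 4 (0.17 log units; within the scatter) and so stays within the scatter. With the chain of compound 3 held constant, this assay therefore does not separate benzyl from 4-methoxybenzyl, and this position accepts a group of 2 heavy atoms, including 1 hydrogen-bond acceptor, without a step that counts. No measurement at hand accounts for this result.

From the compounds shown here alone, it remains open whether another group at this position, such as an amine, a carboxylic acid or a longer alkoxy chain, would produce a step beyond the scatter. Going by these compounds, it is also open whether methoxy would behave in the same way on the benzyl group of compound 1, with its phenyl-ended chain, or of compound 2, with its longer alkyl chain.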